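Swapping trifluoromethyl for carbamoyl on the pyridine

The compounds below may be only part of what the source reports. "The series", "measured", "known", "first", "only" and "open" are said of these compounds alone.

Two measured compounds share one core. In a physicochemical assay for solubility, using the shake flask method, measured as kinetic solubility, with a stated time of 20 h, at pH 2 (a higher number here means a more soluble compound, a lower number a less soluble compound), compound 1 `Fc1cnc(Nc2cc3[nH]c(-c4cccc(C(F)(F)F)c4)nc3cn2)c(F)c1` gives < 5000 nM, which is a limit of the assay rather than a number. Compound 2 `FC(F)(F)c1ccc(Nc2cc3[nH]c(-c4cccc(C(F)(F)F)c4)nc3cn2)nc1` gives < 5000 nM in this assay, again a limit and not a number. Within the data shown here, the only measured step, a step that the two limits leave unreadable from compound 1 to compound 2, cannot be sized, because of the limit of < 5000 nM in this assay, at which 2 of the 2 values shown sit. Compound 3 `NC(=O)c1ccc(Nc2cc3[nH]c(-c4cccc(C(F)(F)F)c4)nc3cn2)nc1` differs from compound 2 by carbamoyl in place of trifluoromethyl on an aromatic carbon. Among the measured compounds shown here, no measured step involves carbamoyl, so the expectation rests on the limit alone. For compound 3 the expected result in this assay is 8000 nM, with a range from 1500 nM to 40000 nM. The step that this estimate means from compound 2 to compound 3 is expected to be an at least 1.6-fold higher number from compound 2 to compound 3 (0.20 log units; that floor lies within the scatter), though a further limit rather than a number remains quite possible.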

Compound 3, solubility: < 5000 nM
Compound 3: only a limit was reported (the forecaster's own chance of this, stated with the estimate: 40%); middle value at least 1.6-fold (0.20 log units) from the limit.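

Compound 3 also gives a limit and not a number in this assay, so no step among compound 1, compound 2 and compound 3 can be read: the limit of < 5000 nM in this assay, at which 3 of the 3 values shown sit.

These compounds leave open whether carbamoyl in place of trifluoromethyl changes the result in this assay at all, and in which direction.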